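Fluoro Added to the Hydroxyphenyl Ring of Compound 2

The compounds below may be only part of what the source reports. "The series", "measured", "known", "first", "only" and "open" are said of these compounds alone.

Going by the values given here, compound 2 `O=C(c1ccc(-c2ccc(O)c(Cl)c2)cc1)c1cccc(O)c1` gives 153 nM in an assay for inhibition of 17-beta-hydroxysteroid dehydrogenase type 2 (Homo sapiens), using microsomes, with a stated time of 20 min (on this read-out lower numbers stand for stronger inhibition and higher numbers for weaker inhibition), the lowest of the two numbers measured so far. Among the compounds with values here, its companion, compound 1 `O=C(c1ccc(-c2ccc(O)c(F)c2)cc1)c1cccc(O)c1`, gives 525 nM in this assay, and the only measured step, a 3.4-fold lower number from compound 1 to compound 2 (0.54 log units; beyond the scatter), concerns chloro in place of fluoro on the other ring. Compound 3 `O=C(c1ccc(-c2ccc(O)c(Cl)c2)cc1)c1ccc(F)c(O)c1` differs from compound 2 by fluoro in place of hydrogen on an aromatic carbon, ortho to a hydroxy group and para to a large group, turning 3-hydroxyphenyl into 4-fluoro-3-hydroxyphenyl. Within the data shown here, no measured step touches this ring, and the halogen swap from compound 1 to compound 2 sits elsewhere, so it offers only a loose hint. This change is therefore expected to move this assay little, if at all beyond the scatter, in either direction. Compound 3 is estimated at 150 nM, within 50 nM to 450 nM, an expected step of a 1.0-fold lower number from compound 2 to compound 3 (0.01 log units; within the scatter).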

Compound 3, half-maximal inhibitory concentration: 24 nM
Estimate against measurement, compound 3: 6.3-fold (0.80 log units) above; the whole stated range lies above it.
By their numbers in this assay, from the lowest: compound 3; then compound 2; then compound 1.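

Going by these compounds alone, the 3-hydroxyphenyl ring had not been touched by any earlier step, and the only change read before, a 3.4-fold lower number from compound 1 to compound 2 (0.54 log units; beyond the scatter), lay on the other ring. Turning that ring into 4-fluoro-3-hydroxyphenyl now gives a 6.4-fold lower number from compound 2 to compound 3 (0.80 log units; beyond the scatter) in this assay, which shows that this position, ortho to a hydroxy group and para to a large group, responds to a single fluoro in place of hydrogen. Nothing shown here accounts for this gain.

As far as these compounds go, whether the gain is specific to fluoro remains open, as does what a methoxy group or a nitrile would do at this same position. From the compounds shown here alone, it is also open whether fluoro here would give a similar step on the core of compound 1, which carries fluoro rather than chloro on the other ring.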